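A few compounds are considered here, and "the series" means these few. Any claim that something is new, unique, unknown or untested is made for them only; others in the source may bear on it.

Measured compounds:
Compound 1 `N#CCn1c2ccc([N+](=O)[O-])cc2c(=O)n1Cc1ccccc1`; in an ADME assay on L929 cells (Mus musculus) for cytotoxicity, read by resazurin assay, with a stated time of 48 h (on this read-out higher numbers stand for lower toxicity in this test and lower numbers for higher toxicity in this test), compound 1 gives > 256000 nM, which is a limit of the assay.
Compound 2 `CNC(=O)CCCn1c2ccc([N+](=O)[O-])cc2c(=O)n1Cc1ccccc1`; in this assay compound 2 gives > 256000 nM, again a limit of the assay.

Compound 2 stands at the limit of > 256000 nM in this assay, at which 2 of the 2 values shown sit, so no toxicity could be read for it within the tested range. Within the data shown here, the one measured step, a step that the two limits leave unreadable from compound 1 to compound 2, is therefore unreadable in size and direction. Compound 3 `Cc1ccc(S(=O)(=O)n2c3ccc([N+](=O)[O-])cc3c(=O)n2Cc2ccccc2)cc1` differs from compound 2 in one place: (4-methylphenyl)sulfonyl in place of 3-(methylcarbamoyl)propyl on an aromatic nitrogen. No measured step bears on this change, and the two shown values give no readable gradient to build on, so the expectation for compound 3 rests on both measured compounds sitting at the limit. Compound 3 is expected to sit near the same limit, with the step of a number no higher from compound 2 to compound 3 (the limit leaves the size open) expected to stay within the scatter. The estimate for compound 3 is 256000 nM, between 50000 nM and 300000 nM.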

Compound 3, concentration lethal to 50% of the cells: > 256000 nM
Compound 3 was reported as a limit; the forecaster's own chance of this, stated with the estimate: 60%; the middle value lies on the limit itself.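

No step among compound 1, compound 2 and compound 3 can be read in this assay, because each result is a limit of the assay and not a number: the limit of > 256000 nM in this assay, at which 3 of the 3 values shown sit.

The compounds shown leave open whether any group on the aromatic nitrogen would give a readable value.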